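Chloro-to-bromo swap on the vinyl halide of compound 1

This account rests on a few compounds, and the source may have more. Where it says the series, first, only, none or still open, it means among the compounds named here.

Measured compounds:
compound 1 `Cc1ccc(S(=O)(=O)N2CC=C(Cl)CC2)cc1` — > 100000 nM
compound 2 `CCCCCCCC1C=C(Cl)CCN1S(=O)(=O)c1ccc(C)cc1` — 92000 nM

Compound 1 `Cc1ccc(S(=O)(=O)N2CC=C(Cl)CC2)cc1` stands only at a limit in a functional assay on A2780 cells (Homo sapiens) for antiproliferative activity, read by sulforhodamine B assay, with a stated time of 48 h; a higher number here means a weaker inhibitor of growth, a lower number a stronger inhibitor of growth: its recorded value > 100000 nM is a limit of the assay, not a number, as noted in the limit of > 100000 nM in this assay, at which 1 of the 2 values shown sits. Compound 2 `CCCCCCCC1C=C(Cl)CCN1S(=O)(=O)c1ccc(C)cc1`, which carries heptyl in place of hydrogen on a saturated ring carbon, gives 92000 nM in this assay. Going by the values given here, the one measured step, an at least 1.0-fold lower number from compound 1 to compound 2 (0.03 log units; that floor lies within the scatter), does not leave the scatter, so the shared core gives essentially no growth inhibition across both measured compounds.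

Compound 3 `Cc1ccc(S(=O)(=O)N2CC=C(Br)CC2)cc1` has not been measured. It differs from compound 1 by bromo in place of chloro on a double-bonded ring carbon. Among the compounds with values here, no measured step touches this position, and the only step available, the heptyl addition from compound 1 to compound 2, changed nothing beyond the scatter. The halogen exchange is therefore expected to leave the weak activity of compound 1 essentially unchanged, with a step of a number no higher from compound 1 to compound 3 (the limit leaves the size open). Compound 3 is estimated at 100000 nM, in the range 40000 nM to 300000 nM, most likely reported again as a limit.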

Compound 3, concentration for 50% growth inhibition: > 100000 nM
Compound 3: only a limit was reported; the forecaster's own chance of this, stated with the estimate: 65%; the middle value lies on the limit itself.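

Compound 1 and compound 3 both stand only at a limit in this assay, so the swap of chloro for bromo gives no readable step: the limit of > 100000 nM in this assay, at which 2 of the 3 values shown sit.

The compounds shown leave open whether bromo and chloro on the double-bonded ring carbon differ at all in growth inhibition once the shared core gives a measurable value.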